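Removing the (cyanomethyl)carbonyl group from compound 1

The source may hold more compounds than are shown below. What is called first, only, known or untested is meant among the compounds shown, and "the series" means these compounds.

Measured so far in a functional assay on HCT-116 cells (Homo sapiens) for cytotoxicity, read by sulforhodamine B assay, with a stated time of 24 h; a lower number here means a stronger inhibitor, a higher number a weaker inhibitor:
- compound 1 `N#CCC(=O)N/N=C1\C(=O)Nc2ccc(S(=O)(=O)N3CCOCC3)cc21`: 10300 nM
- compound 2 `O=C1Nc2ccc(S(=O)(=O)N3CCOCC3)cc2/C1=N/c1ccc(O)cc1`: 27300 nM

Of these two numbers, compound 1 holds the lower one, at 10300 nM, and compound 2 gives 27300 nM. Compound 3 `N/N=C1\C(=O)Nc2ccc(S(=O)(=O)N3CCOCC3)cc21` has not yet been measured in this assay. It derives from compound 1 through one change: hydrogen in place of (cyanomethyl)carbonyl on an amine nitrogen. In words, hydrogen stands in place of (cyanomethyl)carbonyl on an amine nitrogen, and the core of compound 1 stays the same.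

Among the measured compounds shown here, only one measured step bears on this change: a 2.7-fold higher number from compound 1 to compound 2 (0.42 log units; beyond the scatter). That step also replaces what compound 1 carries on the double-bonded nitrogen, and it was modest. For the measured compounds named here, a single step is thin evidence, and the data hold no direct precedent for the bare amino group. Even so, a step of similar size and direction is expected. The expected change is a 2.2-fold higher number from compound 1 to compound 3 (0.35 log units; beyond the scatter), a modest rise by this estimate. For compound 3 the estimated value is 23000 nM, with an expected range of 9000 nM to 55000 nM.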

Compound 3, half-maximal inhibitory concentration: 36300 nM
Estimate against measurement, compound 3: 1.6-fold (0.20 log units) below, and the stated range covers the measured number.
By their numbers in this assay, from the lowest: compound 1; then compounds 2 and 3 (each within the scatter of the next).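

In this assay, taking off the (cyanomethyl)carbonyl group and leaving only hydrogen on the amine nitrogen gives a 3.5-fold higher number from compound 1 to compound 3 (0.55 log units; beyond the scatter) and so isolates the loss of that group, whereas the earlier step also brought in a 4-hydroxyphenyl group in place of the whole substituent on the double-bonded nitrogen. The amino and 4-hydroxyphenyl groups on that nitrogen cannot be told apart, with a 1.3-fold higher number from compound 2 to compound 3 (0.12 log units; within the scatter) and this gap lying within the scatter, so among these three compounds only the ((cyanomethyl)carbonyl)amino group of compound 1 stands apart, and compound 1 is the strongest of them. No measurement on hand accounts for this difference.

The compounds shown leave open which part of the (cyanomethyl)carbonyl group matters, since a plain acetyl group would keep the carbonyl without the nitrile, while a longer chain ending in a nitrile would move the nitrile further out. Also open, from the compounds shown here alone, is how a carboxylic acid in place of the nitrile would read in this assay on the core of compound 1.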